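A Small Ester Extension on Two Related Cores

A few compounds are considered here, and "the series" means these few. Any claim that something is new, unique, unknown or untested is made for them only; others in the source may bear on it.

Measured so far:
Compound 1, `CCCOC(=O)C1=C(C)NC(=O)NC1c1ccoc1`, gives 11%.
Compound 2, `CC1=C(C(=O)OCC(C)C)C(c2ccoc2)NC(=O)N1`, gives 16%.
Compound 3, `COC(=O)C1=C(C)N(C)C(=O)NC1c1cccs1`, gives 15%.

All three were tested in an assay on membranes from HeLa cells for displacement of a labelled ligand from adenosine receptor A3 (Homo sapiens), read by scintillation counting, with a stated time of 180 min, tested at 1 uM; a higher number here means more inhibition at the concentration tested (going by the name of the read-out), a lower number less inhibition. Compound 1 and compound 2 share a core and differ only by methyl in place of hydrogen on a saturated chain carbon bound to two saturated chain carbons. This gave a number 5 percentage points higher from compound 1 to compound 2 (within the scatter), a step within the scatter, so the two numbers cannot be told apart. Compound 3 is built on a different core; how the two cores differ is not broken down here. Its number stands beside that of compound 2 and that of compound 1, all three within the scatter of one another.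

Compound 4, `CCOC(=O)C1=C(C)N(C)C(=O)NC1c1cccs1`, has not yet been measured in this assay. It differs from compound 3 by methyl in place of hydrogen on a saturated chain carbon bound to an oxygen next to a carbonyl group. Among the measured compounds shown here, this is the same kind of change as the one from compound 1 to compound 2: in both a methyl enters where a hydrogen left. The place is not the same, though: in compound 2 the methyl sits on a saturated chain carbon bound to two saturated chain carbons, whereas in compound 4 it sits on a saturated chain carbon bound to an oxygen next to a carbonyl group.

Because a number 5 percentage points higher from compound 1 to compound 2 (within the scatter) stayed within the scatter, the step from compound 3 to compound 4 is expected to be small as well, about a number 3 percentage points higher from compound 3 to compound 4 (within the scatter). Compound 4 is therefore estimated to give 18%, expected to lie between 5% and 32%.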

Compound 4, a percentage reported as inhibition, at one concentration (the size of the read-out at that concentration, not a potency): 2%
Compound 4: the middle estimate sits 16 percentage points above what was measured; measured number outside the range, below it.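

Turning methoxycarbonyl into ethoxycarbonyl gave a number 13 percentage points lower from compound 3 to compound 4 (beyond the scatter) in this assay and this does not match the earlier step on the other core: the same change on two cores in this assay, a number 5 percentage points higher (within the scatter) from compound 1 to compound 2 and a number 13 percentage points lower (beyond the scatter) from compound 3 to compound 4, 18 percentage points apart, beyond the scatter of two such steps. In this series, then, the result of adding a methyl to the ester chain on one core cannot simply be carried over to another core. What this does not show is why the two steps part, since the pairs differ both in their cores and in the place of the methyl, which sits on a saturated chain carbon bound to an oxygen next to a carbonyl group in compound 4 but on a saturated chain carbon bound to two saturated chain carbons in compound 2, and a single pair on each core cannot separate these two differences.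

From the compounds shown here alone, it stays open whether a longer chain on the ester of compound 4 would lower the reading further, hold it or bring it back. Going by these compounds, how a carboxylic acid or an amide in place of the ester would read on either core is also open, as is whether the same methyl change would give a matching step when made at one place on both cores.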